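A few compounds are considered here, and "the series" means these few. Any claim that something is new, unique, unknown or untested is made for them only; others in the source may bear on it.

In an ADME assay on the whole organism for pharmacokinetics, with Mus musculus as the target, at a dose of 10 mg/kg by the oral route (on this read-out higher numbers stand for higher exposure at the dose given and lower numbers for lower exposure), compound 3 (`CC/C(=C(/c1ccc(/C=C/C(=O)O)cc1)c1ccc2[nH]ncc2c1)c1ccccc1C`) gives 7200 ng.h/mL, the second highest of the three numbers, with compound 2 (`CC/C(=C(/c1ccc(/C=C/C(=O)O)cc1)c1ccc2[nH]ncc2c1)c1ccccc1Cl`) at 15000 ng.h/mL and compound 1 (`CC/C(=C(/c1ccc(/C=C/C(=O)O)cc1)c1ccc2[nH]c(=O)oc2c1)c1ccccc1`) at 3000 ng.h/mL. Compound 4 (`CC/C(=C(/c1ccc(/C=C/C(=O)O)cc1)c1ccc2[nH]ncc2c1)c1ccncc1C`) carries 3-methylpyridin-4-yl in place of 2-methylphenyl on a double-bonded chain carbon bound to a double-bonded chain carbon and a saturated chain carbon. Going by the values given here, no measured pair shows this exchange directly. The closest guide is a 2.1-fold lower number from compound 2 to compound 3 (0.32 log units; beyond the scatter), a modest step with methyl in place of chloro on an aromatic carbon. A downward move of similar size is expected in this assay, namely a 2.1-fold lower number from compound 3 to compound 4 (0.31 log units; beyond the scatter). For compound 4 the estimated value is 3500 ng.h/mL, with an expected range from 1200 ng.h/mL to 10000 ng.h/mL.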

Compound 4, area under the concentration-time curve: 81 ng.h/mL
Beside the measured number, compound 4's estimate is 43-fold (1.64 log units) above it; measured number below the stated range.
By their numbers in this assay, from the lowest: compound 4; then compound 1; then compound 3; then compound 2.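

In this assay, going by these compounds alone, the group at this place, on a double-bonded chain carbon bound to a double-bonded chain carbon and a saturated chain carbon, proves far more decisive than the earlier compounds showed: 3-methylpyridin-4-yl in place of 2-methylphenyl brings an 89-fold lower number from compound 3 to compound 4 (1.95 log units; beyond the scatter) and exceeds the modest 2.1-fold lower number from compound 2 to compound 3 (0.32 log units; beyond the scatter) by a wide margin. Set against 2-chlorophenyl, the same ring gives a 190-fold lower number from compound 2 to compound 4 (2.27 log units; beyond the scatter) with no change in heavy-atom count. Going by these compounds, whether 3-chloropyridin-4-yl would fare any better at this place remains open. Nothing shown bears on why exposure falls so steeply.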